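The source may report more compounds than this note shows. Statements on the series, on what has been measured and on what is new or still open speak of the compounds shown alone.

Of the compounds shown here, two on one shared core have been measured so far in a physicochemical assay for solubility, using the shake flask method, in simulated intestinal fluid, measured as kinetic solubility, with a stated time of 2 h, at 25 degrees C, at pH 6.5 (a higher number here means a more soluble compound, a lower number a less soluble compound), to date. Compound 1 (`Cc1noc(-c2nc(C)c3c(c2N)C(=O)N(CC2CCOCC2)C3=O)n1`) gives 5700 nM and compound 2 (`Cc1noc(-c2nc(C)c3c(c2N)C(=O)N(Cc2ccncc2)C3=O)n1`) gives 26400 nM as the higher of the two numbers. Compound 3 (`Cc1noc(-c2nc(C)c3c(c2N)C(=O)N(Cc2ccc(N(C)C)cc2)C3=O)n1`) carries 4-(dimethylamino)phenyl in place of pyridin-4-yl on a saturated chain carbon bound to an amide-type nitrogen in a ring. Going by the values given here, the only measured step at this place, modest but beyond the scatter, is a 4.6-fold higher number from compound 1 to compound 2 (0.67 log units; beyond the scatter) for pyridin-4-yl in place of oxan-4-yl. Among the compounds with values here, compound 3 loses that pyridin-4-yl, so going by a 4.6-fold higher number from compound 1 to compound 2 (0.67 log units; beyond the scatter) a fall of similar or somewhat larger size is expected in this assay as a loose guess, since no measured compound carries the new group. The estimated fall is a sizeable one (a 6.6-fold lower number from compound 2 to compound 3 (0.82 log units; beyond the scatter)). Compound 3 is estimated at 4000 nM (expected range 1000 nM to 15000 nM).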

Compound 3, solubility: 7400 nM
Compound 3: middle estimate off by 1.9-fold (0.27 log units), on the low side; low and high end bracket the measured number.
By their numbers in this assay, from the lowest: compounds 1 and 3 (each within the scatter of the next); then compound 2.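

In this assay, 4-(dimethylamino)phenyl in place of pyridin-4-yl gives a 3.6-fold lower number from compound 2 to compound 3 (0.55 log units; beyond the scatter) and so does not keep the earlier gain of a 4.6-fold higher number from compound 1 to compound 2 (0.67 log units; beyond the scatter) at this saturated chain carbon. The remaining pair gives a 1.3-fold higher number from compound 1 to compound 3 (0.11 log units; within the scatter), so the two groups on compound 1 and compound 3 cannot be told apart here, although only one of them is aromatic, and among these three compounds only compound 2 stands apart. No measurement at hand accounts for this difference.

A plain phenyl or a pyridin-3-yl group at the same place would show whether the gain in compound 2 follows the ring nitrogen or its location within the ring. A dimethylamino group on pyridin-4-yl would show whether the two groups' effects carry over when combined.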